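Compound 2 to Compound 3: a Downward Step Expected

The source may hold more compounds than are shown below. What is called first, only, known or untested is meant among the compounds shown, and "the series" means these compounds.

compound 1 `Nc1ccccc1NC(=O)c1ccc(CSC(=S)N2CCN(Cc3ccccn3)CC2)cc1`: 20.7%
compound 2 `Nc1ccccc1NC(=O)c1ccc(CSC(=S)N2CCc3cc(Cl)ccc32)cc1`: 31.9%

In a functional assay on A-375 cells (Homo sapiens) for antiproliferative activity, read by CCK-8 assay, with a stated time of 72 h, tested at 2 uM (a higher number here means a stronger effect of the compound at the concentration tested, a lower number a weaker effect), compound 2 gives 31.9%, the higher of the two numbers shown. Compound 1 gives 20.7%, a gap below compound 2 that lies beyond the usual scatter. Compound 3 `CN(Cc1ccncc1)C(=S)SCc1ccc(C(=O)Nc2ccccc2N)cc1` is not yet measured; it differs from compound 2 by methyl((pyridin-4-yl)methyl)amino in place of 5-chloro-2,3-dihydro-1H-indol-1-yl on a thiocarbonyl carbon. Among the measured compounds shown here, no measured pair shows this change, so the expectation rests on the two values alone. The step from compound 2 to compound 3 is expected to be downward, beyond the scatter, at a number 10.9 percentage points lower from compound 2 to compound 3 (beyond the scatter). Compound 3 is estimated at 21%, within 9% to 34%.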

Compound 3, a percentage reported as inhibition, at one concentration (the size of the read-out at that concentration, not a potency): 31.4%
Compound 3: middle estimate off by 10.4 percentage points, on the low side, and the stated range covers the measured number.
By their numbers in this assay, from the lowest: compound 1; then compounds 3 and 2 (each within the scatter of the next).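

In this assay, putting methyl((pyridin-4-yl)methyl)amino in place of 5-chloro-2,3-dihydro-1H-indol-1-yl on the thiocarbonyl carbon gives a number 0.5 percentage points lower from compound 2 to compound 3 (within the scatter), so the two groups cannot be told apart at this position. The chlorine and the five-membered non-aromatic ring are thus not needed here for a read-out of this size. Nothing available explains this result. From the compounds shown here alone, what a morpholine or a dimethylamino group would give on this thiocarbonyl carbon remains open.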